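From a Free Amino Group to Dimethylamino

A few compounds are considered here, and "the series" means these few. Any claim that something is new, unique, unknown or untested is made for them only; others in the source may bear on it.

Three measured compounds set the scene in a functional assay on A2780 cells (Homo sapiens) for antiproliferative activity, read by MTT assay, with a stated time of 48 h; a lower number here means a stronger inhibitor, a higher number a weaker inhibitor. Compound 1 `CNCC(=O)Nc1cc(OC)ccc1C(=O)c1ccc(OC)c2c1C=CC(C)(C)O2` gives 1590 nM, compound 2 `C=C(c1ccc(OC)cc1NC(=O)CO)c1ccc(OC)c2c1C=CC(C)(C)O2` gives 280 nM, and compound 3 `C=C(c1ccc(OC)cc1NC(=O)CN)c1ccc(OC)c2c1OC(C)(C)C=C2` gives 80 nM. Compound 3 therefore holds the lowest number of the three. Its gaps to compound 2 and to the more distant compound 1 are both larger than repeated measurements alone would produce.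

The next compound, compound 4 `C=C(c1ccc(OC)cc1NC(=O)CN(C)C)c1ccc(OC)c2c1OC(C)(C)C=C2`, makes a single change to compound 3: dimethylamino in place of amino on a saturated chain carbon bound to a carbonyl carbon. Among the measured compounds shown here, the measured compounds differ from one another in more than one place, so no measured pair shows this change on its own, and any forecast rests on thin ground. For the measured compounds named here, with compound 3 already at 80 nM, the lowest value so far, a modest weakening seems more likely than a further gain. The expected step in this assay is a 2.0-fold higher number from compound 3 to compound 4 (0.30 log units; within the scatter), and this estimate carries wide uncertainty. For compound 4 the estimated value is 160 nM, with an expected range from 45 nM to 600 nM.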

Compound 4, half-maximal inhibitory concentration: 420 nM
Beside the measured number, compound 4's estimate is 2.6-fold (0.42 log units) below it; the range from low to high includes it.
By their numbers in this assay, from the lowest: compound 3; then compounds 2 and 4 (each within the scatter of the next); then compound 1.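

In this assay, among the compounds shown here, replacing amino with dimethylamino on a saturated chain carbon bound to a carbonyl carbon gives a 5.3-fold higher number from compound 3 to compound 4 (0.72 log units; beyond the scatter), the first comparison here in which only one place changes, and it shows that the outcome at this position depends on what the nitrogen carries. Two counted differences arrive together in this single swap: amino has 1 heavy atom and 1 hydrogen-bond donor, while dimethylamino has 3 heavy atoms and 0 hydrogen-bond donors, so this one step cannot separate their contributions. No measurement shown here accounts for the higher number.

As far as these compounds go, it remains open whether a larger group at this position, such as diethylamino or a pyrrolidine ring attached through its nitrogen, would push the number further in the same direction or bring it back. Compound 1 carries methylamino at the matching chain carbon, but it differs from compound 3 and compound 4 in more than one place, so it cannot show how a single methyl group on the nitrogen would act on its own.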